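A few compounds are considered here, and "the series" means these few. Any claim that something is new, unique, unknown or untested is made for them only; others in the source may bear on it.

Of the compounds shown here, three built on one shared core have been tested in a functional assay on the whole organism (Tail, strain ICR) with Mus musculus as the target, in the tail flick test, with a stated time of 90 min, at a dose of 25 umol/kg by the oral route; a higher number here means a stronger effect of the compound at the dose given, a lower number a weaker effect. Compound 1 `CC[C@H](C)[C@H](NC(=O)CN(c1nc(Cl)nc2[nH]cnc12)C1CC1)C(=O)OCc1ccccc1` gives 36.3%. Compound 2 `O=C(CN(c1nc(Cl)nc2[nH]cnc12)C1CC1)N[C@@H](CCC(=O)OCc1ccccc1)C(=O)OCc1ccccc1` gives 50%. Compound 3 `NC(=O)CC[C@H](NC(=O)CN(c1nc(Cl)nc2[nH]cnc12)C1CC1)C(=O)OCc1ccccc1` gives 42.8%. On these numbers compound 3 stands second highest of the three; its nearest neighbour is compound 1 and its furthest is compound 2, and both gaps lie within the scatter. Accordingly the step of a number 6.5 percentage points higher from compound 1 to compound 3 (within the scatter) and the step of a number 7.2 percentage points lower from compound 2 to compound 3 (within the scatter) both stay within the scatter, while a number 13.7 percentage points higher from compound 1 to compound 2 (beyond the scatter) is the only change among the three that reaches beyond it.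

Compound 4 `O=C(CN(c1nc(Cl)nc2[nH]cnc12)C1CC1)N[C@@H](CO)C(=O)OCc1ccccc1` has not yet been measured in this assay. It differs from compound 3 in one place: hydroxy in place of carbamoylmethyl on a saturated chain carbon, two bonds along the chain from an amide-type nitrogen and a carbonyl carbon. Going by the values given here, no measured step exchanges the group at this place for hydroxy, so the closest guides are the two changes already seen at that saturated chain carbon, through which compound 3 is reached from compound 1 and from compound 2 by steps within the scatter. Compound 4 is therefore expected to sit close to compound 3, with an estimated step of a number 4.8 percentage points lower from compound 3 to compound 4 (within the scatter) that does not leave the scatter. The estimate for compound 4 in this assay is 38%, with an expected range from 20% to 56%.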

Compound 4, a percentage reported as activity, at one dose (the size of the read-out at that dose, not a potency): 34.5%
Estimate against measurement, compound 4: 3.5 percentage points above, and the stated range covers the measured number.
By their numbers in this assay, from the lowest: compounds 4, 1, 3 and 2 (each within the scatter of the next, the first and the last beyond it).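

In this assay, cutting the side chain at this saturated chain carbon down to hydroxymethyl costs little against the two closest comparisons: the exchange of carbamoylmethyl for hydroxy reads as a number 8.3 percentage points lower from compound 3 to compound 4 (within the scatter), and the exchange of sec-butyl for hydroxymethyl reads as a number 1.8 percentage points lower from compound 1 to compound 4 (within the scatter). Going by these compounds alone, a chain as short as hydroxymethyl therefore cannot be told apart from sec-butyl or 2-carbamoylethyl at this place, which the earlier compounds, all carrying longer side chains, could not show. The exchange of (benzyloxycarbonyl)methyl for hydroxy is different, with a number 15.5 percentage points lower from compound 2 to compound 4 (beyond the scatter), so this is the second step beyond the scatter at this place and compound 2 stands at one end of both, although compound 3 remains within the scatter of compound 2.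

Nothing measured on these compounds offers an explanation for these steps. As far as these compounds go, it remains open whether a free carboxylic acid or a primary amine at the end of the side chain would keep the read-out of compound 2 or fall back to that of compound 4, and whether a methyl ether of the hydroxymethyl group would change the picture.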